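One more chain carbon on compound 1

The compounds below may be only part of what the source reports. "The series", "measured", "known", "first", "only" and "open" are said of these compounds alone.

Compound 1 `Cn1cc(C2=C(c3nn(CCCn4ccnc4)c4ncccc34)C(=O)N(c3ccccc3)C2=O)c2ccccc21`: 5510 nM
Compound 2 `Cn1cc(C2=C(c3nn(CCCn4ccnc4)c4ncccc34)C(=O)NC2=O)c2ccccc21`: 13800 nM
Compound 3 `Cn1cc(C2=C(c3nn(CCn4ccnc4)c4ncccc34)C(=O)NC2=O)c2ccccc21`: > 100000 nM (a limit of the assay)

In a functional assay on K562 cells (Homo sapiens) for antiproliferative activity, read by MTT assay, with a stated time of 48 h (a lower number here means a stronger inhibitor, a higher number a weaker inhibitor), compound 1 gives the lowest number, and a 2.5-fold higher number from compound 1 to compound 2 (0.40 log units; beyond the scatter) is the step to its nearest neighbour. Compound 4 `Cn1cc(C2=C(c3nn(CCCCn4ccnc4)c4ncccc34)C(=O)N(c3ccccc3)C2=O)c2ccccc21` differs from compound 1 by (1H-imidazol-1-yl)methyl in place of 1H-imidazol-1-yl on a saturated chain carbon, three bonds along the chain from an aromatic nitrogen, which reads as 3-(1H-imidazol-1-yl)propyl to 4-(1H-imidazol-1-yl)butyl. The closest evidence is the chain change running the opposite way, an at least 7.2-fold higher number from compound 2 to compound 3 (0.86 log units; beyond the scatter), seen without the phenyl. The phenyl step concerns another place. Among the compounds with values here, no measured compound carries the longer chain, so a modest fall in the number is expected, not a firm one. The estimated change is a 1.6-fold lower number from compound 1 to compound 4 (0.20 log units; within the scatter) in this assay overall. The expected value for compound 4 is 3500 nM, with an estimated range of 1200 nM to 12000 nM here.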

Compound 4, half-maximal inhibitory concentration: 5030 nM
For compound 4 the middle estimate is 1.4-fold (0.16 log units) below the measured one; low and high end bracket the measured number.
By their numbers in this assay, from the lowest: compounds 4 and 1 (each within the scatter of the next); then compound 2. At a limit, above all of these: compound 3.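

In this assay, going from 3-(1H-imidazol-1-yl)propyl to 4-(1H-imidazol-1-yl)butyl gives a 1.1-fold lower number from compound 1 to compound 4 (0.04 log units; within the scatter), so with the phenyl present this chain position takes a further carbon with no measurable gain or loss. A one-carbon change here is thus not of one size throughout the series: the same change on two cores in this assay, an at least 7.2-fold higher number (0.86 log units; beyond the scatter) from compound 2 to compound 3 and a 1.1-fold higher number (0.04 log units; within the scatter) from compound 4 to compound 1, at least 6.6-fold (0.82 log units) apart, beyond the scatter of two such steps. That gap rests on compound 3, whose value is a limit of the assay: the limit of > 100000 nM in this assay, at which 1 of the 4 values shown sits.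

The two pairs differ in both chain length and core, so the compounds shown leave open which of these sets the size of the step. Also open, on these data alone, is how a longer chain, or an amine in place of the 1H-imidazol-1-yl, would read in this assay.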